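The compounds below may be only part of what the source reports. "The series", "measured", "known", "first", "only" and "open" are said of these compounds alone.

Of the compounds shown here, three have been measured in an assay on isolated protein for inhibition of alpha-ketoglutarate-dependent dioxygenase alkB homolog 3 (Homo sapiens), read by polymerase chain reaction, with a stated time of 1 h; on this read-out higher numbers stand for weaker inhibition and lower numbers for stronger inhibition. Compound 1 `COc1ccc(Cc2c(C)[nH]n(-c3nc4ccccc4[nH]3)c2=O)cc1` gives 630 nM, the lowest of the three numbers. Compound 2 `Oc1c(-c2ccccc2)c(-c2ccccc2)nn1-c1nc2cc(Cl)ccc2[nH]1` gives 2000 nM, and compound 3 `Cc1[nH]n(-c2nc3cc(Cl)ccc3[nH]2)c(=O)c1Cc1ccccc1` gives 4500 nM; both of these are weaker than compound 1 by margins that lie beyond the scatter of this assay, so compound 1 is the strongest inhibitor of the three. No two of these compounds differ in a single place, so no single change can be tied to a step in the numbers.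

Compound 4 `Cc1[nH]n(-c2nc3ccccc3[nH]2)c(=O)c1Cc1ccc(F)cc1` has not been measured. It differs from compound 1 in one place: fluoro in place of methoxy on an aromatic carbon, on an aromatic carbon of a six-membered aromatic ring of carbon only, para to a large group. For the measured compounds named here, nothing among the measured compounds shows what this exchange does. In the absence of such a step, compound 4 is expected to land near compound 1, with at most a modest weakening, an expected step of a 1.4-fold higher number from compound 1 to compound 4 (0.15 log units; within the scatter). Compound 4 is estimated at 900 nM, in a range from 400 nM to 2500 nM.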

Compound 4, half-maximal inhibitory concentration: 600 nM
Compound 4: the middle estimate sits 1.5-fold (0.18 log units) above what was measured; the range from low to high includes it.
By their numbers in this assay, from the lowest: compounds 4 and 1 (each within the scatter of the next); then compound 2; then compound 3.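

In this assay the exchange of methoxy for fluoro on an aromatic carbon, para to a large group, gives a 1.1-fold lower number from compound 1 to compound 4 (0.02 log units; within the scatter) and so leaves the two compounds indistinguishable on this read-out. This is the first step shown at this position, and it indicates that, in this pair, the number holds without the methoxy oxygen and its hydrogen-bond acceptor. No evidence is available on why the 4-methoxyphenyl and 4-fluorophenyl forms read alike. The compounds shown leave open whether an amine, a carboxylic acid or a longer alkoxy chain at this same place would also leave the number unchanged. They also leave open whether the exchange of methoxy for fluoro would read the same way on a core carrying a chloro group.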